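The source may report more compounds than this note shows. Statements on the series, on what has been measured and on what is new or still open speak of the compounds shown alone.

In a functional assay on A549 cells (Homo sapiens) for inhibition, read by sulforhodamine B assay, with a stated time of 74 h (on this read-out higher numbers stand for weaker inhibition and lower numbers for stronger inhibition), three compounds sharing one core have been measured. Compound 1 `O=C1C=CC2(C=C1)OCC(=O)N2S(=O)(=O)c1ccccc1` gives > 10000 nM, which is a limit of the assay and not a number. Compound 3 `O=C1C=CC2(C=C1)OCC(=O)N2S(=O)(=O)c1ccc(C(F)(F)F)cc1` gives > 10000 nM, again a limit. For the measured compounds named here, compound 2 `N#Cc1cccc(S(=O)(=O)N2C(=O)COC23C=CC(=O)C=C3)c1` gives 1910 nM, the only actual number among the three.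

Compound 4 `O=C1C=CC2(C=C1)OCC(=O)N2S(=O)(=O)c1cccc(C(F)(F)F)c1` comes from compound 2 by a single change, trifluoromethyl in place of cyano on an aromatic carbon, meta to a large group: trifluoromethyl in place of cyano on an aromatic carbon. Going by the values given here, two measured steps bear on it. Cyano in place of hydrogen gave an at least 5.2-fold lower number from compound 1 to compound 2 (0.71 log units; beyond the scatter), so compound 4 gives up the one group seen to lower the number. Trifluoromethyl in place of hydrogen gave a step that the two limits leave unreadable from compound 1 to compound 3, so that step offers no size to build on.

A modest move toward weaker inhibition in this assay is therefore expected, and compound 4 may even land at the limit of > 10000 nM in this assay, at which 2 of the 3 values shown sit. The expected change is a 2.6-fold higher number from compound 2 to compound 4 (0.42 log units; beyond the scatter). For compound 4 the estimated value is 5000 nM, with an expected range from 1500 nM to 15000 nM.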

Compound 4, half-maximal inhibitory concentration: 9610 nM
Compound 4: the middle estimate sits 1.9-fold (0.28 log units) below what was measured; the measured number falls inside the stated range.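

In this assay, the exchange at this aromatic carbon, meta to a large group, matters: trifluoromethyl in place of cyano gives a 5.0-fold higher number from compound 2 to compound 4 (0.70 log units; beyond the scatter). Trifluoromethyl in place of hydrogen gives an at least 1.0-fold lower number from compound 1 to compound 4 (0.01 log units; that floor lies within the scatter), so trifluoromethyl at this position shows no lowering beyond the scatter, and cyano remains the only group shown to lower the number. This is the first readable number for a trifluoromethyl compound in the series, and it lies close to the end of the measurable span: the limit of > 10000 nM in this assay, at which 2 of the 4 values shown sit.

The compounds shown leave open whether an amine, a methoxy group or a carboxylic acid on this aromatic carbon would lower the number as cyano does. They also leave open what cyano does on another carbon of the same ring, and the step between the two limits cannot be read.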